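This account rests on a few compounds, and the source may have more. Where it says the series, first, only, none or still open, it means among the compounds named here.

Of the compounds shown here, two on the shared core have numbers so far. In a functional assay on HepG2 cells (Homo sapiens) for inhibition, read by MTT assay, with a stated time of 24 h (on this read-out higher numbers stand for weaker inhibition and lower numbers for stronger inhibition), compound 1 `CC1(C)[C@H]2CC[C@]1(C)N(Cc1cn(-c3ccc(C#N)cc3)nn1)C(=O)C2` gives 50 nM and compound 2 `CC1(C)[C@H]2CC[C@]1(C)N(Cc1cn(-c3ccc(Br)cc3)nn1)C(=O)C2` gives 110 nM, the higher of the two numbers, which makes compound 2 the weaker inhibitor of the pair. Compound 3 `CC1(C)[C@H]2CC[C@]1(C)N(Cc1cn(-c3cccc(Br)c3)nn1)C(=O)C2` carries 3-bromophenyl in place of 4-bromophenyl on an aromatic nitrogen. Within the data shown here, only one measured step is available, a 2.2-fold higher number from compound 1 to compound 2 (0.34 log units; beyond the scatter), and it is modest. Among the measured compounds shown here, that step exchanged one group for another rather than moving the bromine, so it bears on this change only indirectly, and no measured pair shows the effect of such a move. The expected step in this assay is a 1.2-fold higher number from compound 2 to compound 3 (0.07 log units; within the scatter), which is none beyond the scatter, with the direction left open. Compound 3 is expected at 130 nM, with an estimated range of 45 nM to 380 nM.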

Compound 3, half-maximal inhibitory concentration: 20 nM
Beside the measured number, compound 3's estimate is 6.5-fold (0.81 log units) above it, outside the stated range (below it).
By their numbers in this assay, from the lowest: compound 3; then compound 1; then compound 2.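

Working notes on the series: in this assay, the position of the bromine on the phenyl ring matters on its own, since 3-bromophenyl in place of 4-bromophenyl, with the same atoms joined differently, gives a 5.5-fold lower number from compound 2 to compound 3 (0.74 log units; beyond the scatter). The earlier compounds shown here showed only an exchange of one group for another, not a move of the same group. The 3-bromophenyl group also exceeds the 4-cyanophenyl group, with a 2.5-fold lower number from compound 1 to compound 3 (0.40 log units; beyond the scatter), so bromine goes with the higher number only as 4-bromophenyl among these compounds. No evidence on hand accounts for this shift.

Going by these compounds, whether the nitrile of compound 1 responds to the same move remains open. So does whether an amine or a carboxylic acid in place of the bromine of compound 3 would keep the lower number.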